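The source may report more compounds than this note shows. Statements on the series, on what has been measured and on what is new or still open speak of the compounds shown alone.

Among the measured compounds shown here, compound 1, with the structure `N#Cc1cnc(NCc2cnccc2C(F)(F)F)cc1N[C@H]1C[C@H](O)C1`, is the weaker of the two compounds measured so far in an assay on isolated protein for inhibition of protein kinase C theta type (Homo sapiens), read by TR-FRET, with a stated time of 2 h (a higher number here means a weaker inhibitor, a lower number a stronger inhibitor), where compound 1 gives 900 nM. Compound 2, with the structure `N#Cc1cnc(NCc2ccccc2C(F)(F)F)cc1N[C@H]1CC[C@@H](C(N)=O)CC1`, differs from it in more than one place and in this assay compound 2 gives 20 nM, a lower and therefore stronger result than compound 1.

Compound 3, with the structure `CC1(C)C[C@@H](Nc2cc(NCc3cnccc3C(F)(F)F)ncc2C#N)CC[C@@H]1O`, has not been measured yet. It keeps the core of compound 1 and changes a single part: 4-hydroxy-3,3-dimethylcyclohexyl in place of 3-hydroxycyclobutyl on a nitrogen on an aromatic ring. The small ring with its hydroxyl gives way to a larger ring that also carries a hydroxyl, plus two methyl groups.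

For the measured compounds named here, since no single-change step between measured compounds is available, the size of this move in this assay cannot be read off directly. The expectation is that the step from compound 1 to compound 3 goes toward a lower, stronger number, and the estimated step is a 4.5-fold lower number from compound 1 to compound 3 (0.65 log units; beyond the scatter). Compound 3 is accordingly expected to give about 200 nM in this assay, with a likely range from 50 nM to 800 nM.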

Compound 3, half-maximal inhibitory concentration: 120 nM
Compound 3: middle estimate off by 1.7-fold (0.22 log units), on the high side; the range from low to high includes it.
By their numbers in this assay, from the lowest: compound 2; then compound 3; then compound 1.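

In this assay, among the compounds shown here, replacing 3-hydroxycyclobutyl with 4-hydroxy-3,3-dimethylcyclohexyl on the nitrogen on the aromatic ring gives a 7.5-fold lower number from compound 1 to compound 3 (0.88 log units; beyond the scatter) on an otherwise unchanged core, and this is the first direct reading of a single change at this position. It shows that the number responds to what is attached here even when the hydroxyl stays and the counted hydrogen-bond donors and acceptors remain the same, while the group grows from a four-membered to a six-membered ring and gains two methyl groups. The data offer no measured explanation for this step.

Ring size and the two methyl groups changed together, so this single step cannot show how much of the difference belongs to each, and a 4-hydroxycyclohexyl group without the methyl groups would be needed to separate them. Whether the hydroxyl itself matters also remains open, since both groups carry one and neither a plain cyclohexyl group nor an amine in its place appears among the compounds shown.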